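The compounds below may be only part of what the source reports. "The series", "measured", "known", "first", "only" and "open" are said of these compounds alone.

Compound 1 `CC(C)N1CCc2nc(C#Cc3cccc(Cl)c3)ccc2C1=O` gives 100 nM.
Compound 2 `CC(C)N1CCc2nc(C#Cc3ccccn3)ccc2C1=O` gives 2740 nM.
Compound 3 `O=C1c2ccc(C#Cc3cccc(Cl)c3)nc2CCN1C1CCCCC1` gives 12000 nM.

All three numbers come from an assay on HEK293 cells for displacement of a labelled ligand from metabotropic glutamate receptor 5 (Homo sapiens), with a stated time of 2 h; a lower number here means a stronger inhibitor, a higher number a weaker inhibitor. Compound 1 and compound 2 differ by pyridin-2-yl in place of 3-chlorophenyl on a triple-bonded carbon. That change brought a 27-fold higher number from compound 1 to compound 2 (1.44 log units; beyond the scatter). Compound 1 and compound 3 differ in their cores by cyclohexyl in place of isopropyl on an amide-type nitrogen in a ring, and that change brought a 120-fold higher number from compound 1 to compound 3 (2.08 log units; beyond the scatter), so compound 3 already stands as the weakest of the three measured compounds.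

Compound 4 `O=C1c2ccc(C#Cc3ccccn3)nc2CCN1C1CCCCC1` has not yet been measured. It differs from compound 3 by pyridin-2-yl in place of 3-chlorophenyl on a triple-bonded carbon. For the measured compounds named here, this is the same change as the one between compound 1 and compound 2, at the same place, now carried out on the core of compound 3 instead of the core of compound 1. Going by the values given here, only that one earlier example exists, and it lay on a much stronger starting point.

In this assay compound 4 is expected to lose further, with an estimated step of a 13-fold higher number from compound 3 to compound 4 (1.10 log units; beyond the scatter). That expectation rests on the earlier pair, where the same change gave a 27-fold higher number from compound 1 to compound 2 (1.44 log units; beyond the scatter), tempered by the chance that so weak a starting compound as compound 3 runs into the edge of what the assay can report. Compound 4 is therefore estimated at 150000 nM, with a likely range from 30000 nM to 600000 nM.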

Compound 4, inhibition constant: 2240 nM
Compound 4: middle estimate off by 67-fold (1.83 log units), on the high side; the whole stated range lies above it.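

In this assay the swap of 3-chlorophenyl for pyridin-2-yl on the triple-bonded carbon gives a 5.4-fold lower number from compound 3 to compound 4 (0.73 log units; beyond the scatter) on the core of compound 3, which runs opposite to the same swap on the core of compound 1, so the effect of this change does not carry from one core to the other: the same change on two cores in this assay, a 27-fold higher number (1.44 log units; beyond the scatter) from compound 1 to compound 2 and a 5.4-fold lower number (0.73 log units; beyond the scatter) from compound 3 to compound 4, 150-fold (2.17 log units) apart, beyond the scatter of two such steps
Read the other way, cyclohexyl in place of isopropyl gives a 1.2-fold lower number from compound 2 to compound 4 (0.09 log units; within the scatter) when pyridin-2-yl is present, yet a large loss when 3-chlorophenyl is present: the same change on two cores in this assay, a 120-fold higher number (2.08 log units; beyond the scatter) from compound 1 to compound 3 and a 1.2-fold lower number (0.09 log units; within the scatter) from compound 2 to compound 4, 150-fold (2.17 log units) apart, beyond the scatter of two such steps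
The two changes therefore do not act independently in these four compounds, but a single set of four cannot show why, nor whether the same holds elsewhere in the series.

The compounds shown leave open whether this dependence extends to other groups on the amide-type nitrogen, such as ethyl or cyclopentyl. They also leave open whether a plain phenyl on the triple-bonded carbon would follow 3-chlorophenyl or pyridin-2-yl.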